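This account rests on a few compounds, and the source may have more. Where it says the series, first, only, none or still open, it means among the compounds named here.

Measured in a functional assay on DLD-1 cells (Homo sapiens) for cytotoxicity, with a stated time of 48 h; a lower number here means a stronger inhibitor, a higher number a weaker inhibitor:
- compound 1 `CC(C)COc1ccc2oc(/C=C/[S+](C)[O-])cc(=O)c2c1`: 5000 nM
- compound 2 `CCCC(=O)Oc1ccc2oc(/C=C/[S+](C)[O-])cc(=O)c2c1`: 8700 nM
- compound 3 `CCCCC(=O)Oc1ccc2oc(/C=C/[S+](C)[O-])cc(=O)c2c1`: 6700 nM

Compound 3 is not separated from its two neighbours on these numbers: a 1.3-fold lower number from compound 2 to compound 3 (0.11 log units; within the scatter), and a 1.3-fold higher number from compound 1 to compound 3 (0.13 log units; within the scatter). The remaining pair gives the same picture: a 1.7-fold higher number from compound 1 to compound 2 (0.24 log units; within the scatter). The three values therefore form a single group, with no order that can be relied on.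

The next compound is compound 4 `C[S+]([O-])/C=C/c1cc(=O)c2cc(C#N)ccc2o1`, which has yet to be tested in this assay. The change is cyano in place of (butylcarbonyl)oxy on an aromatic carbon.

All three measured steps alter only the group carried on the oxygen, and in every measured compound that oxygen remains on the aromatic carbon. They show tolerance of those exchanges, but none tests the loss of the oxygen or the arrival of cyano, so the change is an extrapolation. No direction can be drawn from the data. The working expectation stays with the group formed by compound 1, compound 2 and compound 3, with no step beyond the scatter and a wide margin on either side.

The expected step is small: a 1.1-fold lower number from compound 3 to compound 4 (0.05 log units; within the scatter).

For compound 4 the estimated value is 6000 nM, with an expected range from 2000 nM to 20000 nM.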

Compound 4, half-maximal inhibitory concentration: > 10000 nM
Compound 4: a limit, no number; the forecaster's own chance of this, stated with the estimate: 12%; at least 1.6-fold (0.22 log units) between middle value and limit.
By their numbers in this assay, from the lowest: compounds 1, 3 and 2 (each within the scatter of the next). At a limit, above all of these: compound 4.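

In this assay compound 4, the first compound shown without an oxygen on this aromatic carbon, gives > 10000 nM, which is a limit of the assay and not a number. The steps to it are floors only: an at least 1.4-fold higher number from compound 3 to compound 4 (0.17 log units; that floor lies within the scatter), an at least 1.1-fold higher number from compound 2 to compound 4 (0.06 log units; that floor lies within the scatter) and an at least 2.0-fold higher number from compound 1 to compound 4 (0.30 log units; that floor lies within the scatter), so all three floors stay within the scatter and compound 4 is not separated from compound 1, compound 2 or compound 3, although no value for it is in hand to place it among them. The tolerance seen among the isobutoxy, (propylcarbonyl)oxy and (butylcarbonyl)oxy compounds is therefore not shown to extend to cyano, and this reading of the position rests on a single limit: the limit of > 10000 nM in this assay, at which 1 of the 4 values shown sits.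

The compounds shown do not separate the loss of the oxygen from the arrival of cyano, and the size of the change remains unknown without a number for compound 4. A hydroxy group, a methoxy group or an amine on this aromatic carbon would bear on both questions, as would a carboxylic acid in place of cyano.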